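This account rests on a few compounds, and the source may have more. Where it says the series, first, only, none or still open, it means among the compounds named here.

Working notes on the series. Three compounds have been run in a functional assay on HEL cells (Homo sapiens) for cytotoxicity (a lower number here means that less compound is tolerated, a higher number that more compound is tolerated), so far. Compound 1 `CCCOCN1c2ccccc2C(=O)NS1(=O)=O` is reported only as a limit of the assay, > 50 ug/mL. Compound 2 `CC(=O)OCCOCN1C(=O)c2ccccc2NS1(=O)=O` likewise is reported only as a limit, > 50 ug/mL. Going by the values given here, compound 3 `O=C1c2ccccc2N(Cc2ccccc2)S(=O)(=O)N1COCc1ccccc1` is the one compound of the three with an actual number, giving 20 ug/mL in this assay; the other two values sit at the limit of > 50 ug/mL in this assay, at which 2 of the 3 values shown sit, so compound 3 stands as the only measured point and the least tolerated of the three as far as the numbers go.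

Compound 4 `O=C1c2ccccc2NS(=O)(=O)N1COCc1ccccc1` has not yet been measured in this assay. It differs from compound 3 in one place: hydrogen in place of benzyl on a sulfonamide nitrogen in a ring. Compound 4 thus carries a hydrogen where compound 3 carries a benzyl on the sulfonamide nitrogen in the ring, while the (benzyloxy)methyl group is retained.

Among the compounds with values here, no step between two measured compounds is available to size this change directly. Given that compounds 1 and 2, both without a benzyl on that nitrogen, sit at the limit of > 50 ug/mL in this assay, at which 2 of the 3 values shown sit, the expectation is that compound 4 is tolerated at a higher concentration than compound 3, a step of a 2.5-fold higher number from compound 3 to compound 4 (0.40 log units; beyond the scatter) in this assay beyond the scatter, with a fair chance that only a limit is reported. Compound 4 is estimated at 50 ug/mL, within a range from 25 ug/mL to 100 ug/mL.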

Compound 4, minimum cytotoxic concentration: > 50 ug/mL
Compound 4 was reported as a limit; the forecaster's own chance of this, stated with the estimate: 60%; the middle value lies on the limit itself.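

Going by these compounds alone, this is the first readable one-place step: hydrogen in place of benzyl on a sulfonamide nitrogen in a ring, with the (benzyloxy)methyl group retained, gives an at least 2.5-fold higher number from compound 3 to compound 4 (0.39 log units; beyond the scatter) in this assay. Compound 1 and compound 2 each differ from compound 3 in more than one place and could not size this change; the pair now ties the lower number of compound 3 to the benzyl at this position, and shows that the (benzyloxy)methyl group without that benzyl does not bring the number down to that of compound 3. The value of compound 4 is a limit, so the step fixes only a floor on the size of the change, and compound 4 joins the compounds reported at that same limit: the limit of > 50 ug/mL in this assay, at which 3 of the 4 values shown sit.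

The step between compound 2 and compound 4, phenyl in place of acetoxymethyl, cannot be read, as both values are limits. Also open, going by these compounds, is whether the lower number follows the aromatic ring of the benzyl or any group at this nitrogen, a question that a methyl or a longer alkyl chain on the sulfonamide nitrogen in a ring would separate.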